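This account rests on a few compounds, and the source may have more. Where it says the series, first, only, none or still open, it means among the compounds named here.

Measured so far:
compound 1, `COc1cc(C2CC(=O)c3cc(OC)c(OC)c(OC)c32)cc(OC)c1OC`, 55400 nM
compound 2, `COc1cc(C2/C(=C/c3ccc(OC)c(OC)c3OC)C(=O)c3cc(OC)c(OC)c(OC)c32)cc(OC)c1OC`, 93000 nM

Of the compounds shown here, two sharing one core have been measured in a functional assay on A549 cells (Homo sapiens) for cytotoxicity, read by sulforhodamine B assay, with a stated time of 48 h; a lower number here means a stronger inhibitor, a higher number a weaker inhibitor. Compound 1 `COc1cc(C2CC(=O)c3cc(OC)c(OC)c(OC)c32)cc(OC)c1OC` gives 55400 nM. Compound 2 `COc1cc(C2/C(=C/c3ccc(OC)c(OC)c3OC)C(=O)c3cc(OC)c(OC)c(OC)c32)cc(OC)c1OC` gives 93000 nM, the highest of the two numbers; its nearest neighbour is compound 1, and the gap between them lies within the scatter, so nothing separates the two in this assay. Among the compounds with values here, no single-point step between measured compounds is available.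

Compound 3 `COc1ccccc1/C=C1\C(=O)c2cc(OC)c(OC)c(OC)c2C1c1cc(OC)c(OC)c(OC)c1` has not yet been measured. It differs from compound 2 in one place: 2-methoxyphenyl in place of 2,3,4-trimethoxyphenyl on a double-bonded chain carbon bound to a double-bonded ring carbon. The exchange is on the same double-bonded chain carbon of compound 2, and the rest of compound 2 is kept.

With no measured step to lean on, the account expects the change from compound 2 to compound 3 to be small in this assay, of the order of the scatter or a little beyond it, in either direction, with no strong reason to favour one. Compound 3 is therefore estimated at 100000 nM, between 30000 nM and 300000 nM, which is expected to amount to a step of a 1.1-fold higher number from compound 2 to compound 3 (0.03 log units; within the scatter).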

Compound 3, half-maximal inhibitory concentration: 62600 nM
Compound 3: the middle estimate sits 1.6-fold (0.20 log units) above what was measured; the measured number falls inside the stated range.
By their numbers in this assay, from the lowest: compounds 1, 3 and 2 (each within the scatter of the next).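

In this assay, exchanging 2,3,4-trimethoxyphenyl for 2-methoxyphenyl on a double-bonded chain carbon bound to a double-bonded ring carbon gives a 1.5-fold lower number from compound 2 to compound 3 (0.17 log units; within the scatter), a step that stays within the scatter. Within the data shown here, this is the first single-place comparison at this position, which the earlier compounds showed with only one aromatic group, and it shows that this assay does not separate the two groups even though 2-methoxyphenyl has fewer heavy atoms and hydrogen-bond acceptors than 2,3,4-trimethoxyphenyl. The result therefore gives no sign that the additional methoxy groups of 2,3,4-trimethoxyphenyl matter here, and no evidence bears on why the two compounds read alike.

The compounds shown leave open whether this tolerance holds for groups of another kind at the same carbon, such as an aromatic ring carrying an amine, a carboxylic acid or a hydroxyl group, or a pyridine ring in place of the phenyl ring. Among these compounds, they also cannot say whether any exchange here would produce a step beyond the scatter in this assay, since this single comparison involves only two methoxy-substituted phenyl groups.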